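Compound 3 to compound 4: hydrogen in place of methoxy

The compounds below may be only part of what the source reports. "The series", "measured", "known", "first", "only" and "open" are said of these compounds alone.

Compound 3 (`COc1cccc(/C=C/C(=O)c2cc(OC)ccc2O)c1`) stands highest of the three measured compounds in a physicochemical assay for lipophilicity (a higher number here means a more lipophilic compound, a lower number a more polar compound), at 3.87 and lies beyond the scatter from both others. Compound 2 (`COc1ccc(C(=O)/C=C/c2c(OC)cccc2OC)c(O)c1`) gives 3.51 and compound 1 (`COc1cc(O)c(C(=O)/C=C/c2cc(OC)c(OC)c(OC)c2)cc1OC`) gives 3.5 in the same assay, and these two values fall within the scatter of each other. Compound 4 (`COc1cccc(/C=C/C(=O)c2ccccc2O)c1`) differs from compound 3 at one place (hydrogen in place of methoxy on an aromatic carbon): hydrogen in place of methoxy on an aromatic carbon. Going by the values given here, no measured pair shows this change alone, so nothing measured fixes its size. The expected step of a number 0.08 log units higher from compound 3 to compound 4 (within the scatter) is a slight rise that stays within the scatter. Compound 4 is estimated at 3.95 (expected range 3.6 to 4.3).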

Compound 4, partition coefficient: 3.94
Estimate against measurement, compound 4: 0.01 log units above; measured number inside the range.
By their numbers in this assay, from the lowest: compounds 1 and 2 (each within the scatter of the next); then compounds 3 and 4 (each within the scatter of the next).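

Hydrogen in place of methoxy on an aromatic carbon, para to a hydroxy group, gives in this assay a step of a number 0.07 log units higher from compound 3 to compound 4 (within the scatter). Going by these compounds alone, this is the first single-place comparison, and it shows that losing the methoxy at this place leaves the read-out within the scatter. No available evidence bears on this result.

On these data alone, only hydrogen and methoxy are compared at this place, so a chlorine atom, an amine or a longer alkoxy chain there remains open. As far as these compounds go, whether the step holds with the other substituents of compound 1 or compound 2 also remains open.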